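The compounds below may be only part of what the source reports. "The series", "measured", "known", "first", "only" and "open" are said of these compounds alone.

Measured so far in a functional assay on BJAB cells (Homo sapiens) for antiproliferative activity, with a stated time of 4 days; on this read-out lower numbers stand for an effect already at smaller amounts and higher numbers for an effect only at larger amounts of compound:
- compound 1 `Cc1c(-c2cc(Cl)cc(Cl)c2)c(C(=O)O)nn1-c1nc(-c2cc(Cl)ccc2F)c(SC(C)C)s1`: 4800 nM
- compound 2 `Cc1nn(-c2nc(-c3ccc(Cl)c(Cl)c3)c(SC(C)C)s2)c(C(=O)O)c1-c1cccc(F)c1`: 900 nM
- compound 3 `Cc1cc(Cl)cc(-c2c(C)nn(-c3nc(-c4ccc(Cl)c(Cl)c4)c(SC(C)C)s3)c2C(=O)O)c1`: 663 nM

Among these three numbers compound 2 stands second highest; compound 3 lies within the scatter of it, while compound 1 gives a clearly higher number. Compound 4 `Cc1nn(-c2nc(-c3ccc(Cl)c(Cl)c3)c(SC(C)C)s2)c(C(=O)O)c1-c1cnccn1` differs from compound 2 in one place: pyrazin-2-yl in place of 3-fluorophenyl on an aromatic carbon. Within the data shown here, the only measured step that alters the same group is a 1.4-fold lower number from compound 2 to compound 3 (0.13 log units; within the scatter), and there one six-membered aromatic ring of carbon only replaced another. Among the measured compounds shown here, a move to pyrazin-2-yl, a ring with 2 hetero atoms, has no measured counterpart here, and compound 1 differs from compound 2 in more than one place. Without a precedent, a modest step to a higher number is expected, a 2.0-fold higher number from compound 2 to compound 4 (0.30 log units; within the scatter), with wide uncertainty. Compound 4 is therefore estimated at 1800 nM in this assay, between 600 nM and 6000 nM.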

Compound 4, half-maximal effective concentration: 14000 nM
Estimate against measurement, compound 4: 7.8-fold (0.89 log units) below, and the stated range ends below it.
By their numbers in this assay, from the lowest: compounds 3 and 2 (each within the scatter of the next); then compound 1; then compound 4.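

On the aromatic carbon of the five-membered ring, swapping one carbon-only ring for another stayed within the scatter, but pyrazin-2-yl gives a 16-fold higher number from compound 2 to compound 4 (1.19 log units; beyond the scatter) and a 21-fold higher number from compound 3 to compound 4 (1.32 log units; beyond the scatter) in this assay. This position therefore does not treat all six-membered aromatic rings alike: the ring with 2 hetero atoms stands apart from both carbon-only rings. Nothing measured here gives a reason for this large step. As far as these compounds go, it remains open whether pyridin-2-yl, with a single ring nitrogen, would fall with the carbon-only rings or with pyrazin-2-yl.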